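The source may report more compounds than this note shows. Statements on the series, on what has been measured and on what is new or still open speak of the compounds shown alone.

Measured so far:
- compound 1, `CCC(C(=O)N1CCN(c2cccc(F)c2)CC1)N1C(=O)CCC1=O`: 0% in a functional assay on the whole organism (strain Swiss) with Mus musculus as the target, in the maximal electroshock model, with a stated time of 1 h, at a dose of 100 mg/kg by the intraperitoneal route; a lower number here means a weaker effect, a higher number a stronger effect of the compound at the dose given
- compound 2, `CC(C(=O)N1CCN(c2ccccc2F)CC1)N1C(=O)CCC1=O`: 0%

Compound 2 stands level with compound 1 at the digits given; in this assay compound 1 and compound 2 both give no measurable effect, and the two values lie within the usual scatter of each other, so no order can be read between them. For the measured compounds named here, no single-point step between measured compounds exists.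

Compound 3, `CCC(C(=O)N1CCN(c2ccccc2F)CC1)N1C(=O)CCC1=O`, is the next member to be tested in this assay. Relative to compound 2 the change is methyl in place of hydrogen on a saturated chain carbon, two bonds along the chain from an amide-type nitrogen in a ring and a carbonyl carbon. Going by the values given here, with both measured compounds at the floor of the read-out, there is no step from which a size can be taken. The step from compound 2 to compound 3 is expected to be no change at the digits printed from compound 2 to compound 3 (within the scatter), that is, none beyond the scatter. Compound 3 is accordingly estimated at 0% in this assay, with a range from 0% to 12%, the upper end allowing for a small reading within the scatter.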

Compound 3, a percentage reported as activity, at one dose (the size of the read-out at that dose, not a potency): 0%
Compound 3: middle estimate and measured number agree at the digits printed, and the stated range covers the measured number.
By their numbers in this assay, from the lowest: compounds 1, 2 and 3 (each within the scatter of the next).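

In this assay methyl in place of hydrogen on a saturated chain carbon, two bonds along the chain from an amide-type nitrogen in a ring and a carbonyl carbon, gives no change at the digits printed from compound 2 to compound 3 (within the scatter) and 2-fluorophenyl in place of 3-fluorophenyl on an amine nitrogen in a ring gives no change at the digits printed from compound 1 to compound 3 (within the scatter) at this dose. For the compounds shown here, these are the only single-place steps so far, and as all three compounds sit at the floor of the read-out, neither step gives a size for its change or shows what lies beneath that floor. No measured information bears on the flat result.

As far as these compounds go, whether a longer chain such as propyl at the chain carbon would lift the read-out off the floor stays open. The same holds for chlorine or methoxy in place of the fluorine on the phenyl ring.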